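Swapping one halogenated phenyl for another on the core

The source may report more compounds than this note shows. Statements on the series, on what has been measured and on what is new or still open speak of the compounds shown alone.

Compound 1 `COc1ccc(-n2ccc(=O)c(C(=O)Nc3ccc(Oc4ccnc5[nH]ccc45)c(F)c3)n2)cc1` gives 46400 nM in a functional assay on PC-3 cells (Homo sapiens) for cytotoxicity, read by MTT assay, with a stated time of 72 h; a lower number here means a stronger inhibitor, a higher number a weaker inhibitor.
Compound 2 `O=C(Nc1ccc(Oc2ccnc3[nH]ccc23)c(F)c1)c1nn(-c2ccccc2)ccc1=O` gives 38600 nM in this assay.
Compound 3 `O=C(Nc1ccc(Oc2ccnc3[nH]ccc23)c(F)c1)c1nn(-c2ccc(Br)cc2F)ccc1=O` gives 8800 nM in this assay.

Compound 3 has the lowest number of the three measured compounds, and its steps to the other two are both beyond the scatter: a 5.3-fold lower number from compound 1 to compound 3 (0.72 log units; beyond the scatter) and a 4.4-fold lower number from compound 2 to compound 3 (0.64 log units; beyond the scatter). Between compound 1 and compound 2 the step is small: a 1.2-fold lower number from compound 1 to compound 2 (0.08 log units; within the scatter).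

Compound 4 `O=C(Nc1ccc(Oc2ccnc3[nH]ccc23)c(F)c1)c1nn(-c2ccc(Cl)c(F)c2)ccc1=O` is not yet measured. It differs from compound 3 in one place: 4-chloro-3-fluorophenyl in place of 4-bromo-2-fluorophenyl on an aromatic nitrogen. The change sits on an aromatic nitrogen of the shared core, next to the ring nitrogen, meta to a large group and para to a group of 1 heavy atom.

The measured steps that bear on this are those from compound 1 and compound 2 to compound 3, each of which replaced an unsubstituted or methoxy-bearing phenyl with a halogenated one and gave a modest gain. Going by the values given here, compound 4 keeps a halogenated phenyl, only with a different halogen and a shifted fluorine, and no measured step shows the effect of such a swap. The expectation for compound 4 is therefore a number close to that of compound 3, a step of a 1.1-fold higher number from compound 3 to compound 4 (0.06 log units; within the scatter) that is not expected to exceed the scatter. Compound 4 is estimated at 10000 nM, with a range from 4000 nM to 25000 nM.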

Compound 4, half-maximal inhibitory concentration: 13600 nM
The estimate for compound 4 lay 1.4-fold (0.13 log units) below the measured number; the measured number falls inside the stated range.
By their numbers in this assay, from the lowest: compounds 3 and 4 (each within the scatter of the next); then compounds 2 and 1 (each within the scatter of the next).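

In this assay the step of a 1.5-fold higher number from compound 3 to compound 4 (0.19 log units; within the scatter) shows that exchanging 4-bromo-2-fluorophenyl for 4-chloro-3-fluorophenyl on this aromatic nitrogen, which changes both the halogen and the place of the fluorine, leaves the number within the usual scatter. The gain seen earlier therefore does not belong to compound 3 alone: the steps of a 2.8-fold lower number from compound 2 to compound 4 (0.45 log units; beyond the scatter) and a 3.4-fold lower number from compound 1 to compound 4 (0.53 log units; beyond the scatter) put a second halogenated phenyl beyond the scatter from both the phenyl and the 4-methoxyphenyl compounds, and none of the four compounds goes against this. No measurement here explains these steps, so the reason for them remains unknown.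

Because the halogen and the fluorine differ together between compound 3 and compound 4, these compounds cannot separate the contribution of each, and a simpler group such as 4-chlorophenyl, with a single halogen, would be needed to begin doing so. Going by these compounds, it also remains open how this position would respond to something other than a halogen or methoxy on the phenyl ring, such as an amine or a carboxylic acid.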